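The source may hold more compounds than are shown below. What is called first, only, known or untested is meant among the compounds shown, and "the series" means these compounds.

Three compounds of the series have been run in an in vitro ADME assay on microsomes from liver (Mus musculus) for pharmacokinetics, read by LC-MS, with a stated time of 10 min, tested at 1 uM; a lower number here means slower removal, a higher number faster removal of the compound. Compound 1 `Cc1ccc(NC(=O)[C@H]2CN(C)C[C@@H]2c2ccc(/C=C/C(=O)Nc3ccccc3N)cc2)cc1` gives 62 mL/min/kg. Compound 2 `CN1C[C@H](C(=O)Nc2ccccc2F)[C@@H](c2ccc(/C=C/C(=O)Nc3ccccc3N)cc2)C1` gives 67 mL/min/kg. Compound 3 `Cc1cc(NC(=O)[C@H]2CN(C)C[C@@H]2c2ccc(/C=C/C(=O)Nc3ccccc3N)cc2)ccc1F` gives 62 mL/min/kg. Compound 3 stands level with compound 1, the two together the lowest of the three numbers, and one of the steps between measured compounds is a 1.1-fold lower number from compound 2 to compound 3 (0.03 log units; within the scatter). The remaining steps, a 1.1-fold higher number from compound 1 to compound 2 (0.03 log units; within the scatter) and no change at the digits printed from compound 1 to compound 3 (within the scatter), are equally small. Each of those three steps exchanges one group built on a six-membered aromatic ring for another on the amide-type nitrogen.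

Compound 4 `CN1C[C@H](C(=O)NC2CC2)[C@@H](c2ccc(/C=C/C(=O)Nc3ccccc3N)cc2)C1` is next: cyclopropyl in place of 4-fluoro-3-methylphenyl on an amide-type nitrogen. Among the measured compounds shown here, no measured step covers an exchange of this kind at that position; the three steps known all stayed within the scatter while the group on the amide-type nitrogen was varied among six-membered aromatic rings, which gives no lead on direction for a three-membered non-aromatic ring. Without precedent, the expected step in this assay is a 1.2-fold lower number from compound 3 to compound 4 (0.09 log units; within the scatter), a move that need not exceed the scatter, and the range is set wide. Compound 4 is expected at 50 mL/min/kg, between 25 mL/min/kg and 100 mL/min/kg.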

Compound 4, clearance: 7 mL/min/kg
Estimate against measurement, compound 4: 7.1-fold (0.85 log units) above; the whole stated range lies above it.
By their numbers in this assay, from the lowest: compound 4; then compounds 1, 3 and 2 (each within the scatter of the next).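

In this assay the group on the amide-type nitrogen proves able to move the number, which the exchanges among six-membered aromatic rings did not show: cyclopropyl gives an 8.9-fold lower number from compound 3 to compound 4 (0.95 log units; beyond the scatter) and a 9.6-fold lower number from compound 2 to compound 4 (0.98 log units; beyond the scatter) and an 8.9-fold lower number from compound 1 to compound 4 (0.95 log units; beyond the scatter), each beyond the scatter. The fall is of similar size whichever of the three aromatic groups leaves, so at this position the contrast lies between those aromatic groups as a set and cyclopropyl. No measurement at hand explains the shift.

Open, as far as these compounds go, is whether the lower number goes with the non-aromatic ring or with the smaller group, since the two change together in this exchange. A cyclohexyl group or a straight propyl chain on the same nitrogen would separate these two readings.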